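This account rests on a few compounds, and the source may have more. Where it says the series, first, only, none or still open, it means among the compounds named here.

Measured compounds:
compound 1 `COc1ccc(-c2ccc3c(NCCCNCc4cccc(OC)c4O)ccnc3c2)cc1`, a physicochemical assay for acid dissociation: 9.47
compound 2 `c1coc(CNCCCNc2ccnc3cc(-c4cccc5ccccc45)ccc23)c1`, this assay: 9.47

In this assay compound 2 gives 9.47, and compound 1 gives 9.47: the two stand level at the digits shown, a gap that lies within the usual scatter, so no order between them can be claimed.

Compound 3 `COc1cccc(CNCCCNc2ccnc3cc(-c4cccc5ccccc45)ccc23)c1O` is not yet measured. It arises from compound 2 by one change: 2-hydroxy-3-methoxyphenyl in place of furan-2-yl on a saturated chain carbon bound to an amine nitrogen. Within the data shown here, no measured pair shows this exact step, so its size is not known from the data. Compound 1, however, already carries the 2-hydroxy-3-methoxybenzyl group on the same chain and gives 9.47, level with compound 2. On that basis the expected step of no change at the digits printed from compound 2 to compound 3 (within the scatter) is none beyond the scatter. Compound 3 is therefore estimated at 9.47, with a range from 9.1 to 9.8.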

Compound 3, acid dissociation constant: 9.47
Estimate against measurement, compound 3: no gap at the digits printed; the range from low to high includes it.
By their numbers in this assay, from the lowest: compounds 1, 2 and 3 (each within the scatter of the next).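

In this assay, among these compounds, the exchange of furan-2-yl for 2-hydroxy-3-methoxyphenyl on a saturated chain carbon bound to an amine nitrogen gives no change at the digits printed from compound 2 to compound 3 (within the scatter) and so offers the first direct reading at this position: the two groups cannot be told apart here, even though the entering group is larger and brings a hydrogen-bond donor. Among the compounds shown here, a second place can also be read for the first time, since naphthalen-1-yl in place of 4-methoxyphenyl on an aromatic carbon gives no change at the digits printed from compound 1 to compound 3 (within the scatter) in the same measurement. No measured evidence on the cause of either result is available here.

As far as these compounds go, whether a carboxylic acid or a simple amine at the position on the chain, or a longer chain, would give a different number remains open. The same question stands for an aromatic carbon carrying a pyridine ring in place of naphthalen-1-yl.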